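The source may hold more compounds than are shown below. What is called first, only, known or untested is meant among the compounds shown, and "the series" means these compounds.

Series notes, cytotoxicity readout. In an ADME assay on BJ cells (Homo sapiens) for cytotoxicity, read by MTT assay, with a stated time of 72 h (a lower number here means a stronger inhibitor, a higher number a weaker inhibitor), compound 1 `COc1ccc(CNc2ncnc3c2ncn3C2CCCCO2)cc1` gives > 100000 nM, a limit of the assay rather than a number. Compound 2 `COc1ccc(CNc2ncnc3c2ncn3C2CCCCO2)cc1OC` gives > 100000 nM in this assay, again a limit. Compound 3 `COc1ccc(OC)c(CNc2ncnc3c2ncn3C2CCCO2)c1` gives > 50000 nM in this assay, also a limit. Two of the three values sit at the limit of > 100000 nM in this assay, at which 2 of the 3 values shown sit, and one at the limit of > 50000 nM in this assay, at which 1 of the 3 values shown sits.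

The change from compound 1 to compound 2 is methoxy in place of hydrogen on an aromatic carbon. The step it makes in this assay is a step that the two limits leave unreadable from compound 1 to compound 2, so the effect of this change cannot be read from the measured pair. How the cores of compound 1 and compound 3 differ is not broken down here.

Compound 4 `COc1cc(OC)c(OC)cc1CNc1ncnc2c1ncn2C1CCCO1` is not yet measured in this assay. Its change from compound 3 is methoxy in place of hydrogen on an aromatic carbon, the same kind of change as that from compound 1 to compound 2, though the surroundings are not identical: in compound 2 the entering group sits ortho to a methoxy group and meta to a large group, whereas in compound 4 it sits ortho to a methoxy group, meta to a methoxy group and para to a large group.

Among the compounds with values here, the only measured instance of this kind of change gave a step that the two limits leave unreadable from compound 1 to compound 2, and every value so far is a limit. On that basis the step from compound 3 to compound 4 in this assay is expected to be a step that the limit leaves unreadable from compound 3 to compound 4, with a limit the most likely outcome. Compound 4 is estimated at 100000 nM, expected to fall between 30000 nM and 300000 nM.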

Compound 4, half-maximal inhibitory concentration: > 100000 nM
Compound 4 was reported as a limit (the forecaster's own chance of this, stated with the estimate: 85%); the middle value lies on the limit itself.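

In this assay compound 3 and compound 4 are both reported as limits, so no step can be read between them, and this second case of methoxy in place of hydrogen on an aromatic carbon is as unreadable as the first. The compounds shown leave open the size of any difference among the four in this assay, including any effect of that methoxy change or of the difference between the core of compound 1 and the core of compound 3.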